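A few compounds are considered here, and "the series" means these few. Any claim that something is new, unique, unknown or untested is made for them only; others in the source may bear on it.

Measured compounds:
- compound 1 `COc1ccc(C(=O)Nc2ccc(Cl)cn2)cc1Nc1nccc(-c2cccnc2)n1`: "not determined" (no result reported) in a functional assay on K562 cells (Homo sapiens) for antiproliferative activity, read by MTT assay, with a stated time of 48 h; a higher number here means a weaker inhibitor, a lower number a stronger inhibitor
- compound 2 `COc1ccc(C(=O)Nc2ncccn2)cc1Nc1nccc(-c2cccnc2)n1`: "not determined" (no result reported) in this assay
- compound 3 `COc1ccc(C(=O)Nc2cccc(Cl)c2)cc1Nc1nccc(-c2cccnc2)n1`: 237000 nM

Within the data shown here, compound 1 stands with "not determined" (no result reported) in this assay; compound 2 likewise gives "not determined" (no result reported), so the only anchor is compound 3, which in this assay gives 237000 nM, a weak inhibitor. Compound 4 `COc1ccc(C(=O)Nc2cccc(C(C)=O)c2)cc1Nc1nccc(-c2cccnc2)n1` differs from compound 1 by 3-acetylphenyl in place of 5-chloropyridin-2-yl on an amide-type nitrogen. Among the measured compounds shown here, no step between measured compounds is available, so the size and direction of this step in this assay cannot be read from the data; the expectation rests on compound 3 alone, whose value 237000 nM places the series in the weak range. Compound 4 is therefore estimated at 150000 nM, with a range of 30000 nM to 700000 nM.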

Compound 4, half-maximal inhibitory concentration: 237000 nM
Estimate against measurement, compound 4: 1.6-fold (0.20 log units) below; the range from low to high includes it.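

In this assay, acetyl in place of chloro on an aromatic carbon gives no change at the digits printed from compound 3 to compound 4 (within the scatter). This first readable step at the group on the amide-type nitrogen does not tell the two substituents apart, and the pair stays in the weak range. No available measurement bears on the reason for this result.

Steps involving compound 1 and compound 2 cannot be read, so the 5-chloropyridin-2-yl group remains unplaced. Going by these compounds, whether an amine or a carboxylic acid on that aromatic carbon would shift the value remains open.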